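The source may hold more compounds than are shown below. What is called first, only, known or untested is meant among the compounds shown, and "the series" means these compounds.

Compound 1 `COc1cccc(OC)c1-c1cc(C(=O)N[C@@H](CCC2CCCCC2)CC(=O)O)nn1-c1ccc(F)cc1`: 5 mL/min/kg
Compound 2 `CCC(O)CNC(=O)C[C@H](CCC1CCCCC1)NC(=O)c1cc(-c2c(OC)cccc2OC)n(CC(C)C)n1`: 389 mL/min/kg

In an ADME assay on microsomes from liver (Homo sapiens) for metabolic stability, read by LC-MS, using NADPH, with a stated time of 120 min, tested at 1 uM (a higher number here means faster removal of the compound, a lower number slower removal), compound 2 gives 389 mL/min/kg, the higher of the two numbers, and compound 1 gives 5 mL/min/kg, a gap beyond the usual scatter. Compound 3 `CC[C@@H](O)CNC(=O)C[C@H](CCC1CCCCC1)NC(=O)c1cc(-c2c(OC)cccc2OC)n(CC(C)C)n1` follows from compound 2 through one change: the two compounds have the same atoms and bonds; at least one stereo element is drawn with a configuration in one of them and without one in the other: 1 of 2 stereo elements differ; a stereocentre at a saturated chain carbon is drawn without a configuration in compound 2 and R in compound 3. Nothing is added or removed. A stereocentre at a saturated chain carbon is drawn without a configuration in compound 2 and R in compound 3. Within the data shown here, no measured pair shows what such a change does, so little movement is expected, with no firm direction. The expected step, a 1.1-fold lower number from compound 2 to compound 3 (0.05 log units; within the scatter), lies within the scatter. Compound 3 is estimated at 350 mL/min/kg, with a range of 170 mL/min/kg to 700 mL/min/kg.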

Compound 3, clearance: 402 mL/min/kg
Compound 3: middle estimate off by 1.1-fold (0.06 log units), on the low side; the range from low to high includes it.
By their numbers in this assay, from the lowest: compound 1; then compounds 2 and 3 (each within the scatter of the next).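

Setting the saturated chain carbon stereocentre to R gives a 1.0-fold higher number from compound 2 to compound 3 (0.01 log units; within the scatter) in this assay, so this assay does not separate the two drawings. Among these compounds, this is the first measured pair to isolate that stereocentre, and it shows that defining it as R leaves the clearance within the usual scatter. The only difference at this position is this: the fact that one of compounds 2 and 3 is drawn with a defined configuration and the other without, at the place where they differ

The compounds shown leave open how the S configuration at this carbon would read. They also leave open what an amine in place of the hydroxyl on this chain would do to the clearance.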